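Swapping fluoro for bromo on a benzylidene ketone

The source may report more compounds than this note shows. Statements on the series, on what has been measured and on what is new or still open speak of the compounds shown alone.

Of the compounds shown here, three have been measured in a functional assay on L1210 cells (Mus musculus) for inhibition; on this read-out lower numbers stand for stronger inhibition and higher numbers for weaker inhibition. Compound 1, `COc1cccc(/C=C2\Cc3ccccc3C2=O)c1OC`, gives 214000 nM in this assay. Compound 2, `O=C1/C(=C/c2ccccc2F)CCc2ccccc21`, gives 22800 nM. Compound 3, `O=C1/C(=C/c2ccccc2Br)CCCc2ccccc21`, gives 37000 nM. Compound 2 and compound 3 lie within the usual scatter of each other, so neither can be called the more potent of the two; compound 1 sits beyond the scatter from compound 2, with a clearly higher number.

Compound 4, `O=C1/C(=C/c2ccccc2Br)CCc2ccccc21`, has not yet been measured. It differs from compound 2 in one place: bromo in place of fluoro on an aromatic carbon. Among the measured compounds this particular exchange has not been followed on an otherwise unchanged core. Compound 3, which carries the bromo group on a core that is one ring atom larger, gives a number close to that of compound 2, so no change beyond the scatter is expected from this step. Compound 4 is therefore estimated to give 26000 nM in this assay, within a range of 8000 nM to 80000 nM, and the expected step of a 1.1-fold higher number from compound 2 to compound 4 (0.06 log units; within the scatter) is small.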

Compound 4, half-maximal inhibitory concentration: 33400 nM
Beside the measured number, compound 4's estimate is 1.3-fold (0.11 log units) below it; the measured number falls inside the stated range.
By their numbers in this assay, from the lowest: compounds 2, 4 and 3 (each within the scatter of the next); then compound 1.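

For the compounds shown here, for the first time, bromo in place of fluoro is followed on an otherwise unchanged core: in this assay the step is a 1.5-fold higher number from compound 2 to compound 4 (0.17 log units; within the scatter). At this place, on an aromatic carbon ortho to a large group, the read-out therefore does not separate these two halogens, so neither compound 2 nor compound 4 can be called the stronger inhibitor. No measurement shown here offers an explanation for this result.

From the compounds shown here alone, both groups compared are single halogen atoms, so it remains open whether a quite different group at the same place, such as an amine or a carboxylic acid, would shift the number beyond the scatter. Going by these compounds, it also remains open whether the same exchange would give so small a step elsewhere on this aromatic ring.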